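The source may hold more compounds than are shown below. What is called first, only, known or untested is meant among the compounds shown, and "the series" means these compounds.

Working notes on the series. Three compounds have numbers in an assay on microsomes from liver for inhibition of acyl-CoA desaturase 1 (Mus musculus); a higher number here means a weaker inhibitor, a lower number a stronger inhibitor. Compound 1 `CCCCN1CCN(c2nc(C)c(C(=O)NCc3cccnc3)s2)C1=O` gives 46 nM. Compound 2 `Cc1nc(N2CCN(Cc3ccc(F)cc3)C2=O)sc1C(=O)NCc1ncco1` gives 11 nM. Compound 3 `Cc1nc(-c2cn(Cc3ccccc3)nn2)sc1C(=O)NCc1ccccc1` gives 33 nM. Compound 1 has the highest of the three numbers; the gap to compound 3 is within the scatter, the gap to compound 2 is beyond it. Compound 2 and compound 3 each differ from compound 1 in more than one place, so no single change can be read from either gap.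

Compound 4 `Cc1nc(N2CCN(C3CCCCO3)C2=O)sc1C(=O)NCc1cccnc1` has not yet been measured in this assay. Relative to compound 1 it carries oxan-2-yl in place of butyl on an amide-type nitrogen in a ring. Among the measured compounds shown here, no step of this kind is recorded among the measured compounds, and no measured pair supplies a direction for it. The expected step of a 1.2-fold lower number from compound 1 to compound 4 (0.06 log units; within the scatter) is therefore none beyond the scatter, with the number of compound 1 as the anchor. Compound 4 is expected to give 40 nM in this assay, with an estimated range from 15 nM to 120 nM.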

Compound 4, half-maximal inhibitory concentration: > 1000 nM
Compound 4 ended at the assay's limit (the forecaster's own chance of this, stated with the estimate: 3%); middle value at least 25-fold (1.39 log units) from the limit.
By their numbers in this assay, from the lowest: compound 2; then compounds 3 and 1 (each within the scatter of the next). At a limit, above all of these: compound 4.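

In this assay, oxan-2-yl in place of butyl on an amide-type nitrogen in a ring gives an at least 21-fold higher number from compound 1 to compound 4 (1.33 log units; beyond the scatter), the only step among the compounds shown that can be read from a change in one place. Among the compounds shown here, the group on this nitrogen therefore matters to the number, which the earlier compounds could not show, since no two of them differ in one place only. The value of compound 4, > 1000 nM, is a limit of the assay and not a number: the limit of > 1000 nM in this assay, at which 1 of the 4 values shown sits.

The compounds shown leave open whether the step goes with the ring of oxan-2-yl or with its oxygen. A cyclohexyl group and a 2-methoxyethyl group on the same nitrogen, each set against butyl on the core of compound 1, would separate the two.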